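This account rests on a few compounds, and the source may have more. Where it says the series, first, only, none or still open, it means among the compounds named here.

Measured compounds and their values:

Compound 1 `CN1CCc2nc(C#Cc3ccccc3)sc2C1` in an assay on HEK293 cells for negative allosteric modulation of metabotropic glutamate receptor 5 (Homo sapiens), read by FLIPR, with a stated time of 1 h (a higher number here means a weaker inhibitor, a lower number a stronger inhibitor), gives > 10000 nM, which is a limit of the assay rather than a number.
Compound 2 `CN1CCc2nc(C#Cc3cccc(F)c3)sc2C1` in this assay gives > 10000 nM, again a limit.
Compound 3 `O=C(C1CCCC1)N1CCc2nc(C#Cc3ccccc3)sc2C1` in this assay gives > 10000 nM, also a limit.

Compound 1 therefore stands at the edge of what this assay can report, and so do the other two: the limit of > 10000 nM in this assay, at which 3 of the 3 values shown sit. Compound 2 carries a fluoro in place of hydrogen on an aromatic carbon, and the step that the two limits leave unreadable from compound 1 to compound 2 cannot be read from two limits. Compound 3 carries a cyclopentylcarbonyl in place of methyl on the amine nitrogen in the ring, and the step that the two limits leave unreadable from compound 1 to compound 3 is equally unreadable.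

The next compound, compound 4 `O=C(C1CCCO1)N1CCc2nc(C#Cc3ccccc3)sc2C1`, differs from compound 1 as follows: (oxolan-2-yl)carbonyl in place of methyl on an amine nitrogen in a ring. For the measured compounds named here, of the measured steps, the one from compound 1 to compound 3 bears most on this change, since both replace the methyl on the same ring nitrogen with a carbonyl bearing a five-membered ring; that step stayed unreadable at the limit. Going by the values given here, with compound 1 already at the limit and no measured step showing a gain, no step beyond the scatter is expected, and the value is expected to remain a limit. Compound 4 is estimated at 20000 nM, with a range from 8000 nM to 100000 nM. The step expected from this estimate is a step that the limit leaves unreadable from compound 1 to compound 4.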

Compound 4, half-maximal inhibitory concentration: > 10000 nM
Compound 4: no number, only a limit; the forecaster's own chance of this, stated with the estimate: 85%; the middle value does not contradict the limit.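

In this assay compound 4 gives > 10000 nM, again a limit and not a number. Neither the step from compound 1 to compound 4 nor the one from compound 3 to compound 4 can be read: the limit of > 10000 nM in this assay, at which 4 of the 4 values shown sit.

The compounds shown leave open whether any of these changes alters inhibition at all, and by how much.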